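The compounds below may be only part of what the source reports. "The series", "measured", "known", "first", "only" and "open" are said of these compounds alone.

Three compounds share one core and differ only in the group on the sulfonyl sulfur. Compound 1 `Cc1ccc(S(=O)(=O)c2cnc3ccc(F)cc3c2N2CCC(C)CC2)cc1` carries a 4-methylphenyl there, compound 2 `CC1CCN(c2c(S(=O)(=O)c3ccccc3)cnc3cc(Cl)ccc23)CC1` a plain phenyl, and compound 3 `CC1CCN(c2c(S(=O)(=O)c3cccc(F)c3)cnc3ccc(F)cc23)CC1` a 3-fluorophenyl. In an assay on isolated protein for displacement of a labelled ligand from metabotropic glutamate receptor 5 (Homo sapiens), with a stated time of 60 min, tested at 1 uM (a higher number here means more inhibition at the concentration tested (going by the name of the read-out), a lower number less inhibition), compound 1 gives 91%, compound 2 gives 93% and compound 3 gives 76%. The numbers of compound 2 and compound 1 lie within the scatter of each other, so neither can be called higher; compound 3 sits below both, beyond the scatter.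

Compound 4 `CC1CCN(c2c(S(=O)(=O)c3cc(Cl)cc(Cl)c3)cnc3cc(Cl)ccc23)CC1` has not yet been measured in this assay. It differs from compound 2 in one place: 3,5-dichlorophenyl in place of phenyl on a sulfonyl sulfur. Within the data shown here, the only measured step at the same position is a number 15 percentage points lower from compound 1 to compound 3 (beyond the scatter), a modest loss when one substituted phenyl replaced another. That step suggests changes here cost little, so a similar or somewhat smaller number is expected for compound 4, without a direction that is certain. The step of a number 11 percentage points lower from compound 2 to compound 4 (beyond the scatter) is therefore estimated as small. Compound 4 is expected to give about 82%, likely between 62% and 96%.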

Compound 4, a percentage reported as inhibition, at one concentration (the size of the read-out at that concentration, not a potency): 93%
Compound 4: middle estimate off by 11 percentage points, on the low side; the measured number falls inside the stated range.
By their numbers in this assay, from the lowest: compound 3; then compounds 1, 2 and 4 (each within the scatter of the next).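

Replacing phenyl with 3,5-dichlorophenyl on the sulfonyl sulfur gives no change at the digits printed from compound 2 to compound 4 (within the scatter) in this assay and so costs no measurable inhibition at the concentration tested. Among these compounds, the earlier step of a number 15 percentage points lower from compound 1 to compound 3 (beyond the scatter) showed only that a swap at this place can lower the number, while the new step adds that this phenyl ring can also carry chlorine without a measurable loss. Nothing measured here explains why one change lowers the number and the other does not.

From the compounds shown here alone, a read-out at one concentration is not a potency, so any difference in potency between compound 2 and compound 4 remains unknown. Also open, going by these compounds, is whether this sulfonyl sulfur would accept a cyclohexyl ring, or a phenyl ring carrying a carboxylic acid or an amine.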